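A few compounds are considered here, and "the series" means these few. Any claim that something is new, unique, unknown or untested is made for them only; others in the source may bear on it.

Measured compounds:
Compound 1, `O=c1n(Cc2cc3cc(Cl)ccc3n2CCCCO)c2cnccc2n1C1CC1`, gives > 50000 nM, a limit of the assay.
Compound 2, `O=c1n(Cc2cc3cc(Cl)ccc3n2CCCCF)c2cnccc2n1C1CC1`, gives > 50000 nM, a limit of the assay.
Compound 3, `O=c1n(Cc2cc3cnccc3n2CCCCF)c2cnccc2n1C1CC1`, gives > 50000 nM, a limit of the assay.

The read-out is an ADME assay on HeLa cells (Homo sapiens) for cytotoxicity, read by ATP content, with a stated time of 3 days; on this read-out higher numbers stand for lower toxicity in this test and lower numbers for higher toxicity in this test. In this assay compound 1 reaches only > 50000 nM, which is a limit and not a number. Compound 2 likewise stops at > 50000 nM, again a limit. Compound 3 also sits at > 50000 nM, a limit as well.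

The change from compound 2 to compound 1 is hydroxy in place of fluoro on a saturated chain carbon, four bonds along the chain from an aromatic nitrogen. Its step, a step that the two limits leave unreadable from compound 2 to compound 1, cannot be read in size, because the limit of > 50000 nM in this assay, at which 3 of the 3 values shown sit, holds both ends of it. The cores of compound 3 and compound 2 differ, but that difference is not broken down here.

The unmeasured compound 4, `O=c1n(Cc2cc3cnccc3n2CCCCO)c2cnccc2n1C1CC1`, is related to compound 3 by hydroxy in place of fluoro on a saturated chain carbon, four bonds along the chain from an aromatic nitrogen, the same change that links compound 2 to compound 1. Since that earlier pair left no readable step, the expectation for compound 4 rests on the three limits alone, all of which sit at the limit of > 50000 nM in this assay, at which 3 of the 3 values shown sit. Compound 4 is therefore expected to show a step that the limit leaves unreadable from compound 3 to compound 4 from compound 3, which means no measurable change. On that basis compound 4 is estimated at 80000 nM in this assay, with a likely range from 40000 nM to 200000 nM, and most probably it will again be reported only as a limit.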

Compound 4, half-maximal cytotoxic concentration: > 100000 nM
Compound 4: only a limit was reported (the forecaster's own chance of this, stated with the estimate: 85%); middle value at least 1.2-fold (0.09 log units) from the limit.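

In this assay compound 4 gives > 100000 nM, which is a limit of the assay and not a number. Compound 3 also stands at a limit, so no step can be read between compound 3 and compound 4. The compounds shown leave open at what concentration any of them would reach the half-maximal cytotoxic effect, and whether hydroxy in place of fluoro alters that concentration at all.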